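The source may report more compounds than this note shows. Statements on the series, on what has been measured and on what is new or still open speak of the compounds shown alone.

Compound 1 `CCc1ccc2[nH]c(=O)c(CN(Cc3ccc(C(C)(C)C)cc3)Cc3ccc(F)c(F)c3)cc2c1` is known in a toxicity assay on MDCK cells (Canis lupus familiaris) for cytotoxicity, read by crystal violet staining, with a stated time of 48 h (on this read-out lower numbers stand for higher toxicity in this test and higher numbers for lower toxicity in this test), only through a limit: compound 1 gives > 33000 nM. Compound 2 `COc1ccc(CN(Cc2ccc(C(C)(C)C)cc2)Cc2cc3cc(C)ccc3[nH]c2=O)cc1` likewise reaches only a limit in this assay, giving > 10000 nM. Compound 3 `Cc1ccc2[nH]c(=O)c(CN(Cc3ccc(C(C)(C)C)cc3)[C@H](C)c3ccc(F)cc3)cc2c1` also shows a limit in this assay, giving > 5000 nM. For the measured compounds named here, the single step between measured compounds, a step that the two limits leave unreadable from compound 2 to compound 3, is thus unreadable, bounded by the limits the limit of > 10000 nM in this assay, at which 1 of the 3 values shown sits, and (the limit of > 5000 nM in this assay, at which 1 of the 3 values shown sits). Compound 4 `CCc1ccc2[nH]c(=O)c(CN(Cc3ccc(C(C)(C)C)cc3)C(C)c3ccc(OC)cc3)cc2c1` differs from compound 1 by 1-(4-methoxyphenyl)ethyl in place of 3,4-difluorobenzyl on an amine nitrogen. Going by the values given here, no measured step bears on this change, and every value shown is a limit, so no step beyond the scatter is expected in this assay. Compound 4 is therefore expected to give 30000 nM, between 8000 nM and 100000 nM, most likely again as a limit. The expected step of an at least 1.1-fold lower number from compound 1 to compound 4 (0.04 log units; that floor lies within the scatter) is accordingly one within the scatter.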

Compound 4, half-maximal cytotoxic concentration: > 5000 nM
Compound 4 ended at the assay's limit (the forecaster's own chance of this, stated with the estimate: 80%); the middle value does not contradict the limit.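

Compound 1 and compound 4 are both known only through limits in this assay, and the step between them cannot be read. The compounds shown leave open at what concentration any of them becomes cytotoxic.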